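A triazole diol replaces a basic side chain

The source may report more compounds than this note shows. Statements on the series, on what has been measured and on what is new or still open speak of the compounds shown alone.

In a toxicity assay on HEK-293T cells (Homo sapiens) for cytotoxicity, read by MTT assay, with a stated time of 72 h (on this read-out lower numbers stand for stronger inhibition and higher numbers for weaker inhibition), compound 3 `CN(C)CCCCn1c2c(c3ccccc31)C(=O)c1c[n+]([O-])c3ccccc3c1C2=O` gives 520 nM, the lowest of the three numbers. Compound 2 `O=C1c2c[n+]([O-])c3ccccc3c2C(=O)c2c1c1ccccc1n2Cc1cn([C@@H]2C[C@H](O)[C@@H](CO)O2)nn1` gives 820 nM, within the scatter of compound 3, while compound 1 `O=C1c2c[n+]([O-])c3ccccc3c2C(=O)c2c1c1ccccc1n2Cc1cn([C@H]2C[C@H](O)[C@@H](CO)O2)nn1` gives 3600 nM, beyond it. Going by the values given here, the only single-change step, a 4.4-fold lower number from compound 1 to compound 2 (0.64 log units; beyond the scatter), rests on (the fact that compounds 1 and 2 differ only in the configuration as drawn). Compound 4 `O=C1c2c[n+]([O-])c3ccccc3c2C(=O)c2c1c1ccccc1n2Cc1cn(C[C@H](O)CO)nn1` carries 1-(2,3-dihydroxypropyl)-1H-1,2,3-triazol-4-yl in place of 3-(dimethylamino)propyl on a saturated chain carbon bound to an aromatic nitrogen. Among the compounds with values here, no measured step swaps a group of this kind, so that one stereochemical step offers little guidance; among the triazole-bearing compounds, compound 1 sits above compound 3 and compound 2 within its scatter. Compound 4 is therefore expected to show a small rise, a 2.9-fold higher number from compound 3 to compound 4 (0.46 log units; beyond the scatter). The estimate for compound 4 is 1500 nM, ranging from 500 nM to 5000 nM.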

Compound 4, half-maximal inhibitory concentration: 8880 nM
For compound 4 the middle estimate is 5.9-fold (0.77 log units) below the measured one, outside the stated range (above it).
By their numbers in this assay, from the lowest: compounds 3 and 2 (each within the scatter of the next); then compound 1; then compound 4.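

In this assay the change from 3-(dimethylamino)propyl to 1-(2,3-dihydroxypropyl)-1H-1,2,3-triazol-4-yl is a large penalty at this position (a 17-fold higher number from compound 3 to compound 4 (1.23 log units; beyond the scatter)). Putting 2,3-dihydroxypropyl in place of 4-hydroxy-5-(hydroxymethyl)oxolan-2-yl on an aromatic nitrogen also raises the number, by a large step from one starting point (an 11-fold higher number from compound 2 to compound 4 (1.03 log units; beyond the scatter)) and a modest one from the other (a 2.5-fold higher number from compound 1 to compound 4 (0.39 log units; beyond the scatter)). The same swap therefore gives steps of different size, and configuration alone separates its two starting points: the fact that compounds 1 and 2 differ only in the configuration as drawn.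

From the compounds shown here alone, whether an amine in place of 2,3-dihydroxypropyl on the triazole would bring the number back towards that of compound 3 stays open.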